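An aryl amide swap on the shared core

The compounds below may be only part of what the source reports. "The series", "measured", "known", "first", "only" and "open" are said of these compounds alone.

Measured compounds:
- compound 1 `COc1cc(-c2nnc(SCC(=O)c3ccc(C(F)(F)F)cc3)n2N)cc(OC)c1OC` gives > 100000 nM in a functional assay on HepG2 cells (Homo sapiens) for antiproliferative activity, read by MTT assay, with a stated time of 48 h (on this read-out lower numbers stand for stronger inhibition and higher numbers for weaker inhibition), a limit of the assay.
- compound 2 `COc1cc(-c2nnc(SCC(=O)c3ccc(F)cc3)n2N)cc(OC)c1OC` gives 90400 nM in this assay.
- compound 3 `COc1cc(-c2nnc(SCC(=O)Nc3ccc(C)cc3)n2N)cc(OC)c1OC` gives > 100000 nM in this assay, a limit of the assay.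

Compound 3 therefore stands at the assay limit, and the limit of > 100000 nM in this assay, at which 2 of the 3 values shown sit, shows that compound 1 stands at the same limit. Only compound 2 gives a number.

Compound 4 `COc1cc(-c2nnc(SCC(=O)Nc3ccccc3F)n2N)cc(OC)c1OC` differs from compound 3 by 2-fluorophenyl in place of 4-methylphenyl on an amide-type nitrogen. Among the measured compounds shown here, no measured step changes this same position. The nearest change is the fluorine-for-trifluoromethyl swap giving an at least 1.1-fold lower number from compound 1 to compound 2 (0.04 log units; that floor lies within the scatter), a step that stays within the scatter, while an at least 1.1-fold higher number from compound 2 to compound 3 (0.04 log units; that floor lies within the scatter) and a step that the two limits leave unreadable from compound 1 to compound 3 are bounded by the limit and cannot be sized. Nothing among these steps points to a change beyond the scatter for compound 4, so the step of a number no higher from compound 3 to compound 4 (the limit leaves the size open) is expected to be negligible. Compound 4 is therefore expected to give about 100000 nM, with a range from 40000 nM to 300000 nM, and most likely again only a limit.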

Compound 4, half-maximal inhibitory concentration: 18700 nM
For compound 4 the middle estimate is 5.3-fold (0.73 log units) above the measured one, outside the stated range (below it).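

On the amide-type nitrogen, 2-fluorophenyl in place of 4-methylphenyl produces a change beyond the scatter in this assay, with an at least 5.3-fold lower number from compound 3 to compound 4 (0.72 log units; beyond the scatter). The amide compound 4 also separates from both compounds that carry an aryl group directly on the carbonyl carbon: the swap from 4-fluorophenyl to (2-fluorophenyl)amino gives a 4.8-fold lower number from compound 2 to compound 4 (0.68 log units; beyond the scatter), and the swap from 4-(trifluoromethyl)phenyl to the same group gives an at least 5.3-fold lower number from compound 1 to compound 4 (0.72 log units; beyond the scatter). Two of these three steps are floors rather than full sizes: the limit of > 100000 nM in this assay, at which 2 of the 4 values shown sit.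

The effect of the fluorine cannot yet be told apart from that of its place on the ring, and 4-fluorophenyl and 2-methylphenyl on this same nitrogen would be the direct tests. On these data alone, how 2-chlorophenyl or 2-methoxyphenyl would behave here also stays open.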